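The compounds below may be only part of what the source reports. "The series", "measured", "known", "first", "only" and "open" are said of these compounds alone.

Measured compounds:
- compound 1 `COc1cn2ncc(-c3ccnc(OC(C)(C)C)c3)c2nc1-c1cnn(C)c1`, which in an ADME assay on microsomes from liver (Rattus norvegicus) for metabolic stability, with a stated time of 60 min, tested at 1 uM (a lower number here means that less of the compound is left, a higher number that more of the compound is left), gives 61%
- compound 2 `COc1cc(-c2cnn3cc(OC)c(C4CCOC4)nc23)ccn1`, which in this assay gives 34%
- compound 3 `COc1cn2ncc(-c3ccnc(OC4CC4)c3)c2nc1-c1cnn(C)c1`, which in this assay gives 32%

Compound 2 holds the second highest of the three numbers; its value and that of compound 3 lie within the scatter of each other, while compound 1 sits beyond the scatter above it.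

Compound 4 `COc1cnc2c(-c3ccnc(OC)c3)cnn2c1` differs from compound 2 by hydrogen in place of oxolan-3-yl on an aromatic carbon, so the oxolan-3-yl leaves and a hydrogen enters on the aromatic carbon described.

Going by the values given here, the only measured step, a number 29 percentage points lower from compound 1 to compound 3 (beyond the scatter), concerns a different place, the oxygen on an aromatic ring, and is modest. Among the compounds with values here, no measured step touches the place changed in compound 4, so the expectation rests on compound 2 alone: a step within the scatter, a number 4 percentage points higher from compound 2 to compound 4 (within the scatter), is expected. Compound 4 is estimated at 38%, with a range from 18% to 60%.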

Compound 4, percent of the compound remaining: 10%
Beside the measured number, compound 4's estimate is 28 percentage points above it, outside the stated range (below it).
By their numbers in this assay, from the lowest: compound 4; then compounds 3 and 2 (each within the scatter of the next); then compound 1.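

In this assay, hydrogen in place of oxolan-3-yl on the aromatic carbon gives a number 24 percentage points lower from compound 2 to compound 4 (beyond the scatter) and leaves compound 4 lowest of the series. Going by these compounds alone, the earlier step concerned only the oxygen on an aromatic ring, so this pair is the first sign that the group on this carbon also bears on the compound remaining. No available evidence explains the difference.

A single pair cannot separate the loss of oxolan-3-yl from the loss of any group here. From the compounds shown here alone, whether a methyl group, an amine or a longer chain on this carbon would match compound 2 remains open.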